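A few compounds are considered here, and "the series" means these few. Any claim that something is new, unique, unknown or untested is made for them only; others in the source may bear on it.

Compound 1 `CCCSc1nc(Cl)c2c(n1)N(Cc1ccccc1)C(C(=O)NCCNC(=O)OC(C)(C)C)N2`: > 64000 nM in a functional assay on TE-1 cells (Homo sapiens) for antiproliferative activity, read by MTT assay, with a stated time of 72 h; on this read-out lower numbers stand for stronger inhibition and higher numbers for weaker inhibition.
Compound 2 `CCCSc1nc(Cl)c2c(n1)N(Cc1ccccc1)C(C(=O)Nc1ccccc1)N2`: > 64000 nM in this assay.

For compound 1 the value given is a limit of the assay rather than a measured number. For compound 2 the value is likewise only a limit. The step that the two limits leave unreadable from compound 1 to compound 2 cannot be read, as the limit of > 64000 nM in this assay, at which 2 of the 2 values shown sit. Compound 3 `CCCSc1nc(Cl)c2c(n1)N(Cc1ccccc1)C(C(=O)NCCCc1ccccc1)N2` differs from compound 2 by 3-phenylpropyl in place of phenyl on an amide-type nitrogen. No readable measured step bears on this change, and both values shown are limits. Compound 3 is expected to remain at the limit as well, an expected step that the limit leaves unreadable from compound 2 to compound 3. The estimate for compound 3 is 100000 nM, within a range from 30000 nM to 300000 nM.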

Compound 3, half-maximal inhibitory concentration: 23000 nM
Beside the measured number, compound 3's estimate is 4.3-fold (0.64 log units) above it, outside the stated range (below it).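

Going by these compounds alone, putting 3-phenylpropyl on the amide-type nitrogen gives the first readable number in this assay, with an at least 2.7-fold lower number from compound 2 to compound 3 (0.44 log units; beyond the scatter). Benzyl in place of (tert-butoxycarbonyl)amino on a saturated chain carbon, two bonds along the chain from that nitrogen, gives an at least 2.7-fold lower number from compound 1 to compound 3 (0.44 log units; beyond the scatter). This shows that a change at this one place on the shared core can bring a compound within the range of the assay.

As far as these compounds go, whether a longer chain or an amine on this chain would lower the number further remains open. The true size of both steps also remains open, because only compound 3 has a measured number: the limit of > 64000 nM in this assay, at which 2 of the 3 values shown sit.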